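Adding a methyl to the ester carbon of compound 2

A few compounds are considered here, and "the series" means these few. Any claim that something is new, unique, unknown or untested is made for them only; others in the source may bear on it.

Three esters of a hydroxy acid on a shared adenine-bearing core were measured in a functional assay on PRK cells (Oryctolagus cuniculus) for cytotoxicity; a lower number here means that less compound is tolerated, a higher number that more compound is tolerated. Compound 1 `CCCCOC(=O)C(O)Cn1cnc2c(N)ncnc21` gives 200 ug/mL. Compound 2 `CC(C)OC(=O)C(O)Cn1cnc2c(N)ncnc21` gives > 400 ug/mL, which is a limit of the assay and not a number. Compound 3 `CC(C)COC(=O)C(O)Cn1cnc2c(N)ncnc21` gives > 400 ug/mL, also a limit of the assay. Two of the three values therefore sit at the limit of > 400 ug/mL in this assay, at which 2 of the 3 values shown sit, and compound 2 stands at that limit, so only a floor is known for it.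

Compound 4 `CC(C)(C)OC(=O)C(O)Cn1cnc2c(N)ncnc21` differs from compound 2 by methyl in place of hydrogen on a saturated chain carbon bound to an oxygen next to a carbonyl group and two saturated chain carbons. Among the compounds with values here, the steps that bear on this change are an at least 2.0-fold higher number from compound 1 to compound 3 (0.30 log units; that floor lies within the scatter), at the same kind of carbon, and a step that the two limits leave unreadable from compound 2 to compound 3, whose size the two limits hide. Branching at that carbon has so far not lowered the tolerated concentration, so no step beyond the scatter is expected for a number no higher from compound 2 to compound 4 (the limit leaves the size open), and compound 4 will most likely again sit at the limit. Compound 4 is estimated at 400 ug/mL, within 200 ug/mL to 800 ug/mL.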

Compound 4, minimum cytotoxic concentration: > 400 ug/mL
Compound 4 was reported as a limit; the forecaster's own chance of this, stated with the estimate: 70%; the middle value sits exactly at the limit.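

In this assay, tert-butyl on the oxygen now gives the same reading as isopropyl and isobutyl, a limit of the assay and not a number, and compound 1 alone has a measured value: the limit of > 400 ug/mL in this assay, at which 3 of the 4 values shown sit. The steps from compound 2 and from compound 3 to compound 4 cannot be read, as both ends of each are limits. Within the data shown here, the one readable comparison sets the tert-butyl ester against the butyl ester, and it is an at least 2.0-fold higher number from compound 1 to compound 4 (0.30 log units; that floor lies within the scatter).

Going by these compounds, how far the true values of compound 2, compound 3 and compound 4 differ from one another stays unknown. The compounds shown also do not tell how a carboxylic acid in place of the ester, or a longer chain on the oxygen, would read.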